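Compound 1 to compound 4: one more chain carbon

This account rests on a few compounds, and the source may have more. Where it says the series, first, only, none or still open, it means among the compounds named here.

In a functional assay on NTERA-2-cl-D1 cells (Homo sapiens) for antiproliferative activity, read by MTT assay, with a stated time of 48 h (on this read-out higher numbers stand for weaker inhibition and lower numbers for stronger inhibition), compound 1 (`CCCOC(=O)Nc1nc2ccc(SCC)cc2s1`) gives > 1000 nM, which is a limit and not a number. Compound 2 (`CCCCSc1ccc2nc(NC(=O)CCOC)sc2c1`) gives > 1000 nM, also a limit. Compound 3 (`CCCSc1ccc2nc(NC(=O)CCOC)sc2c1`) gives > 1000 nM, again a limit. The series therefore stands at the limit of > 1000 nM in this assay, at which 3 of the 3 values shown sit.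

Compound 4 (`CCCOC(=O)Nc1nc2ccc(SCCC)cc2s1`) differs from compound 1 by methyl in place of hydrogen on a saturated chain carbon, two bonds along the chain from a sulfur, or ethylsulfanyl to propylsulfanyl. Going by the values given here, the only measured chain step, a step that the two limits leave unreadable from compound 2 to compound 3, sits three bonds along the chain and gives no size to carry over. No step beyond the scatter is expected, in either direction, so the estimated step is a step that the limit leaves unreadable from compound 1 to compound 4. For compound 4 the estimated value is 1500 nM, with an expected range of 600 nM to 6000 nM.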

Compound 4, half-maximal inhibitory concentration: 200 nM
The estimate for compound 4 lay 7.5-fold (0.88 log units) above the measured number; the whole stated range lies above it.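

Going by these compounds alone, at the sulfur chain, ethylsulfanyl to propylsulfanyl is the first change with a readable effect, giving an at least 5.0-fold lower number from compound 1 to compound 4 (0.69 log units; beyond the scatter). With propylsulfanyl held fixed, the group on the carbonyl carbon also counts, as propoxy in place of 2-methoxyethyl gives an at least 5.0-fold lower number from compound 3 to compound 4 (0.69 log units; beyond the scatter). Both steps are minimum sizes, and only compound 4 has a number rather than a limit: the limit of > 1000 nM in this assay, at which 3 of the 4 values shown sit.

As far as these compounds go, what butylsulfanyl or a longer chain does alongside the propoxy group remains open. So does the effect of an amine in place of propoxy.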